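The compounds below may be only part of what the source reports. "The series", "measured", "known", "first", "only" and "open" are said of these compounds alone.

Three compounds share one core and differ only in the group on an aromatic carbon: compound 1 `O=S(=O)(c1ccccc1)n1ccc2c(O)cccc21` carries a hydroxy, compound 2 `O=S(=O)(c1ccccc1)n1ccc2c(N3CCCCC3)cccc21` a piperidin-1-yl and compound 3 `CN(C)c1cccc2c1ccn2S(=O)(=O)c1ccccc1` a dimethylamino. In an assay on isolated protein for displacement of a labelled ligand from 5-hydroxytryptamine receptor 6 (Homo sapiens), read by scintillation counting, with a stated time of 1 h (on this read-out higher numbers stand for weaker inhibition and lower numbers for stronger inhibition), compound 1 gives 108 nM, compound 2 gives 128 nM and compound 3 gives 65 nM. The steps are small: a 1.2-fold higher number from compound 1 to compound 2 (0.07 log units; within the scatter), a 1.7-fold lower number from compound 1 to compound 3 (0.22 log units; within the scatter) and a 2.0-fold lower number from compound 2 to compound 3 (0.29 log units; within the scatter). Compound 3 has the lowest of the three numbers, but each of its steps to the others lies within the scatter, so the three stand level.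

Compound 4 `CN(C)c1cccc2c1ccn2S(C)(=O)=O` changes a different part of the molecule: methyl in place of phenyl on a sulfonyl sulfur. Among the compounds with values here, none of the measured steps touches the sulfonyl group; all three measured compounds keep the phenyl there, and the measured steps only exchange the group on the aromatic carbon. The data therefore give no direct guide, and the change is larger in size than any measured one. For compound 4 the estimate in this assay is 2000 nM, within a wide range from 300 nM to 15000 nM, which means an expected step of a 31-fold higher number from compound 3 to compound 4 (1.49 log units; beyond the scatter).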

Compound 4, inhibition constant: 4720 nM
Compound 4: the middle estimate sits 2.4-fold (0.37 log units) below what was measured; the measured number falls inside the stated range.
By their numbers in this assay, from the lowest: compounds 3, 1 and 2 (each within the scatter of the next); then compound 4.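

Within the data shown here, until this point the phenyl on the sulfonyl sulfur had stayed fixed, so the earlier compounds said nothing about that position. In this assay, methyl in place of phenyl gives a 73-fold higher number from compound 3 to compound 4 (1.86 log units; beyond the scatter), a step far larger than any seen among the groups on the aromatic carbon. With the dimethylamino group kept, then, this single exchange on the sulfonyl sulfur weakens inhibition clearly, although no measurement shown explains why.

This one step cannot separate the loss of the aromatic ring from the loss of carbon atoms, so a cyclohexyl or a butyl chain on the sulfonyl sulfur would be the informative comparison. As far as these compounds go, it also remains open whether the same exchange would have a similar effect with the hydroxy or piperidin-1-yl group on the aromatic carbon.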